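Growth inhibition series: cyano for benzoyl on the triazole aryl

A few compounds are considered here, and "the series" means these few. Any claim that something is new, unique, unknown or untested is made for them only; others in the source may bear on it.

Measured compounds:
- compound 1 `COc1ccc([C@@H]2C/C(=N/OCc3cn(-c4ccccc4CO)nn3)c3cc(CC=C(C)C)c(OC)cc3O2)cc1` — 100%
- compound 2 `COc1cc2c(cc1CC=C(C)C)C(=O)C[C@@H](c1ccc(Oc3ccc(F)cc3)cc1)O2` — 19%
- compound 3 `COc1ccc([C@@H]2C/C(=N/OCc3cn(-c4ccc(C(=O)c5ccccc5)cc4)nn3)c3cc(CC=C(C)C)c(OC)cc3O2)cc1` — 40%

In a functional assay on PC-3 cells (Homo sapiens) for inhibition, read by sulforhodamine B assay, with a stated time of 48 h, tested at 50 uM (on this read-out higher numbers stand for more inhibition of growth at the one concentration tested and lower numbers for less inhibition of growth), compound 1 gives 100%, compound 2 gives 19% and compound 3 gives 40%. Compound 3 thus stands second of the three numbers: it sits beyond the scatter above compound 2 and well beyond the scatter below compound 1. Among the measured compounds shown here, none of the three pairs differ in one place only, so no single-point step is available as a guide.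

Compound 4 `COc1ccc([C@@H]2C/C(=N/OCc3cn(-c4ccc(C#N)cc4)nn3)c3cc(CC=C(C)C)c(OC)cc3O2)cc1` keeps the core and the triazole linker of compound 3 and changes only the substituent on the pendant phenyl ring: cyano in place of benzoyl on an aromatic carbon. Both groups carry one acceptor and no donor, and the change is far from the fused core. For the measured compounds named here, no measured pair isolates this kind of change, so there is no basis for expecting a step beyond the scatter in either direction in this assay.

Compound 4 is therefore expected near compound 3, estimated at 42% with a range of 15% to 75%. The expected step of a number 2 percentage points higher from compound 3 to compound 4 (within the scatter) is estimated to lie within the scatter.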

Compound 4, percent growth inhibition at one concentration: 50%
Compound 4: the middle estimate sits 8 percentage points below what was measured; low and high end bracket the measured number.
By their numbers in this assay, from the lowest: compound 2; then compounds 3 and 4 (each within the scatter of the next); then compound 1.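

In this assay the exchange of benzoyl for cyano on the aromatic carbon para to a large group gives a number 10 percentage points higher from compound 3 to compound 4 (within the scatter) and so leaves the read-out unresolved, although 8 heavy atoms give way to 2 and the ring is lost. The first large single-place step comes from the group on the aromatic nitrogen: 4-cyanophenyl in place of 2-(hydroxymethyl)phenyl gives a number 50 percentage points lower from compound 1 to compound 4 (beyond the scatter) and marks that substituent as the part of the series to which growth inhibition responds. No data at hand bear on the reason for either step.

Still open, from the compounds shown here alone, is whether the hydroxymethyl group itself or its place on the phenyl ring carries the large step. Also open, going by these compounds, is how an amine or a carboxylic acid would read on the aromatic carbon that holds the cyano in compound 4.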